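Trimethoxyphenyl amide on a shared core: cytotoxicity outlook

This account rests on a few compounds, and the source may have more. Where it says the series, first, only, none or still open, it means among the compounds named here.

Compound 1 `COc1ccc(NC(=O)c2csc(-c3cn(Cc4ccc(Cl)cc4)c4ccccc34)n2)cc1` gives a limit of > 100000 nM in an ADME assay on HEK-293T cells (Homo sapiens) for cytotoxicity, read by MTT assay, with a stated time of 48 h, in the presence of a further agent that is not named here; on this read-out higher numbers stand for weaker inhibition and lower numbers for stronger inhibition.
Compound 2 `O=C(Nc1ccccc1)c1csc(-c2cn(Cc3ccc(Cl)cc3)c3ccccc23)n1` gives a limit of > 100000 nM in this assay.
Compound 3 `O=C(Nc1ccccc1)c1csc(-c2c[nH]c3ccccc23)n1` gives a limit of > 100000 nM in this assay.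

Compound 2 therefore stands at a limit only, not at a number. The two measured steps, a step that the two limits leave unreadable from compound 1 to compound 2 and a step that the two limits leave unreadable from compound 2 to compound 3, cannot be read because of the limit of > 100000 nM in this assay, at which 3 of the 3 values shown sit. Compound 4 `COc1cc(NC(=O)c2csc(-c3cn(Cc4ccc(Cl)cc4)c4ccccc34)n2)cc(OC)c1OC` differs from compound 2 by 3,4,5-trimethoxyphenyl in place of phenyl on an amide-type nitrogen. For the measured compounds named here, no measured step touches the amide-type nitrogen, and the nearest one, which alters a methoxy on an aromatic carbon, is itself unreadable, so no direction can be drawn in this assay. Compound 4 is expected at 120000 nM, within 40000 nM to 400000 nM. The expected step is a step that the limit leaves unreadable from compound 2 to compound 4, most likely again a limit.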

Compound 4, half-maximal inhibitory concentration: > 100000 nM
Compound 4 gave a limit, no number; the forecaster's own chance of this, stated with the estimate: 85%; the middle value lies beyond the limit too.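

Neither new step, compound 4 against compound 2 or against compound 1, can be read, because every value is a limit: the limit of > 100000 nM in this assay, at which 4 of the 4 values shown sit.

The compounds shown leave open whether 3,4,5-trimethoxyphenyl in place of phenyl on the amide-type nitrogen changes cytotoxicity at all in this assay.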